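Piperidinol series: benzyl variation on the ring amine

The source may hold more compounds than are shown below. What is called first, only, known or untested is meant among the compounds shown, and "the series" means these compounds.

Measured so far in an assay on Sf21 cells for inhibition of ubiquitin carboxyl-terminal hydrolase 7 (Homo sapiens), read by spectrophotometry, with stated times of 30 min and 2 h; on this read-out lower numbers stand for stronger inhibition and higher numbers for weaker inhibition:
Compound 1 `O=c1c2cnn(-c3ccc(F)cc3)c2ncn1CC1(O)CCN(Cc2cccnc2)CC1`: "not determined" (no result reported).
Compound 2 `O=c1c2cnn(-c3ccc(F)cc3)c2ncn1CC1(O)CCN(Cc2ccc(Cl)cc2)CC1`: 8000 nM.
Compound 3 `COC(=O)c1ccccc1CN1CCC(O)(Cn2cnc3c(cnn3-c3ccc(F)cc3)c2=O)CC1`: "not determined" (no result reported).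

Among the measured compounds shown here, compound 3 stands without a single number in this assay; the same holds for compound 1, so the only anchor in the group is compound 2. The step to be followed goes to compound 4 `O=c1c2cnn(-c3ccc(F)cc3)c2ncn1CC1(O)CCN(Cc2ccc(Br)cc2Cl)CC1`, with the change (4-bromo-2-chlorophenyl in place of 2-(methoxycarbonyl)phenyl on a saturated chain carbon bound to an amine nitrogen in a ring). For the measured compounds named here, no step between measured compounds can be sized here, and the distance from compound 3 to compound 4 cannot be set against any reported change. What can be said is that compound 4 carries a halogen-bearing benzyl close in kind to that of compound 2, whose value in this assay is 8000 nM. On that footing compound 4 is expected to land in the same weak region, with wide uncertainty, estimated at 8000 nM, ranging from 2000 nM to 30000 nM. A reported limit rather than a number is a real possibility.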

Compound 4, half-maximal inhibitory concentration: 1900 nM
For compound 4 the middle estimate is 4.2-fold (0.62 log units) above the measured one, and the stated range ends above it.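

Working from the one anchor in this assay, the aryl group on a saturated chain carbon bound to an amine nitrogen in a ring now has a sized step: 4-bromo-2-chlorophenyl in place of 4-chlorophenyl gives a 4.2-fold lower number from compound 2 to compound 4 (0.62 log units; beyond the scatter). The position therefore responds to a change in halogen substitution on the aryl group, with the rest of the structure unchanged, although the step is modest. No measured evidence accounts for this step.

Going by these compounds, whether 4-bromophenyl or 2-chlorophenyl alone would reproduce this step remains open, so the step cannot yet be divided between the two halogens. Also open, on these data alone, is how this position would respond to a group of another kind on the aryl ring, such as a carboxylic acid or an amine.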